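The source may hold more compounds than are shown below. What is called first, only, known or untested is meant among the compounds shown, and "the series" means these compounds.

Working notes on the shared core of compound 1 `CCOC(=O)c1cnc(N2CCN(Cc3cccc(F)c3)CC2)nc1Oc1c(C)cc(-c2ccc(C#N)cc2)cc1C`, compound 2 `CCOC(=O)c1cnc(N2CCN(Cc3ccc(C(=O)OC)cc3)CC2)nc1Oc1c(C)cc(-c2ccc(C#N)cc2)cc1C` and compound 3 `CCOC(=O)c1cnc(N2CCN(Cc3cccc(Br)c3)CC2)nc1Oc1c(C)cc(-c2ccc(C#N)cc2)cc1C`, which differ only in the group on a saturated chain carbon bound to an amine nitrogen in a ring. In an ADME assay on MT4 cells (Homo sapiens) for cytotoxicity, read by MTT assay, with a stated time of 4 days (on this read-out lower numbers stand for higher toxicity in this test and higher numbers for lower toxicity in this test), compound 1 reports a limit, > 125000 nM. In this assay compound 2 likewise reports a limit, > 125000 nM. In this assay compound 3 also reports only a limit, > 125000 nM. Every step among them is therefore unreadable: a step that the two limits leave unreadable from compound 1 to compound 2, a step that the two limits leave unreadable from compound 1 to compound 3 and a step that the two limits leave unreadable from compound 2 to compound 3; all three rest on (the limit of > 125000 nM in this assay, at which 3 of the 3 values shown sit). Compound 3 thus stands at the limit, indistinguishable from the other two on the numbers shown.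

Compound 4 `CCOC(=O)c1ccc(CN2CCN(c3ncc(C(=O)OCC)c(Oc4c(C)cc(-c5ccc(C#N)cc5)cc4C)n3)CC2)cc1` is to be measured. The change from compound 3: 4-(ethoxycarbonyl)phenyl in place of 3-bromophenyl on a saturated chain carbon bound to an amine nitrogen in a ring. The step bearing most directly on it is a step that the two limits leave unreadable from compound 2 to compound 3, 4-(methoxycarbonyl)phenyl against 3-bromophenyl, and it is unreadable; the same holds for a step that the two limits leave unreadable from compound 1 to compound 2. Nothing measured here points to a readable step in this assay in either direction. An expected step of a number no higher from compound 3 to compound 4 (the limit leaves the size open) follows. The estimate for compound 4 is 125000 nM, between 60000 nM and 300000 nM, most likely reported again as a limit.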

Compound 4, half-maximal cytotoxic concentration: > 125000 nM
Compound 4 was reported as a limit; the forecaster's own chance of this, stated with the estimate: 85%; the middle value lies on the limit itself.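

In this assay compound 4 also reports only a limit, > 125000 nM. No step from compound 1, compound 2 or compound 3 to compound 4 can be read: the limit of > 125000 nM in this assay, at which 4 of the 4 values shown sit.

The compounds shown leave open whether the group on a saturated chain carbon bound to an amine nitrogen in a ring affects this read-out at all.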